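The source may report more compounds than this note shows. Statements on the series, on what has been measured and on what is new or still open speak of the compounds shown alone.

Measured so far in a functional assay on Jurkat cells (Homo sapiens) for antiproliferative activity, read by WST assay, with a stated time of 72 h; on this read-out higher numbers stand for weaker inhibition and lower numbers for stronger inhibition:

- compound 1 `COc1ccc2[nH]c(-c3nc(C)no3)cc2c1`: 19900 nM
- compound 2 `Cc1noc(-c2cc3cc(F)ccc3[nH]2)n1`: 22900 nM
- compound 3 `Cc1noc(-c2cc3cc(Cl)ccc3[nH]2)n1`: 21600 nM

On these numbers compound 1 sits at the low end of the three, yet the steps of a 1.2-fold higher number from compound 1 to compound 2 (0.06 log units; within the scatter) and a 1.1-fold higher number from compound 1 to compound 3 (0.04 log units; within the scatter) both fall within the scatter, as does a 1.1-fold lower number from compound 2 to compound 3 (0.03 log units; within the scatter), so nothing separates the three compounds in this assay. All three measured steps concern the substituent on the aromatic carbon of the shared core and leave the five-membered ring untouched.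

Compound 4 `COc1ccc(-c2noc(-c3cc4cc(OC)ccc4[nH]3)n2)cc1` arises from compound 1 by a change at a different place: 4-methoxyphenyl in place of methyl on an aromatic carbon. Within the data shown here, none of the measured steps bears on this position, so there is no directly comparable step from which to read off a direction or a size. What the three measured compounds do show is that the only variation tried so far moved the numbers by amounts within the scatter, leaving the series at a uniform level in this assay.

Among the measured compounds shown here, with no guiding step, compound 4 is expected to land near compound 1, with the step of a 1.3-fold lower number from compound 1 to compound 4 (0.12 log units; within the scatter) carrying wide uncertainty in either direction. The estimate for compound 4 in this assay is 15000 nM, within a range from 3000 nM to 60000 nM.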

Compound 4, half-maximal inhibitory concentration: > 50000 nM
Compound 4 ended at the assay's limit (the forecaster's own chance of this, stated with the estimate: 15%); middle value at least 3.3-fold (0.52 log units) away from the limit.
By their numbers in this assay, from the lowest: compounds 1, 3 and 2 (each within the scatter of the next). At a limit, above all of these: compound 4.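

Among these compounds, the position on the five-membered ring, between two ring nitrogen atoms, proves not to be neutral in this assay: 4-methoxyphenyl in place of methyl gives an at least 2.5-fold higher number from compound 1 to compound 4 (0.40 log units; beyond the scatter), the first step that lies beyond the scatter, and it points toward weaker inhibition. The substituent changes on the aromatic carbon of the shared core had left the numbers level, so this is the only place among those shown where a change has moved the read-out. The true size of the step cannot be read, since the value for compound 4 is a limit of the assay and not a number: the limit of > 50000 nM in this assay, at which 1 of the 4 values shown sits.

The compounds shown leave open whether this step belongs to the added phenyl ring or to the methoxy group it carries, and a single change cannot show how the position responds more generally. On these data alone, how an unsubstituted phenyl, an ethyl chain or an amine in place of methyl would read in this assay also remains open, including whether any group at this position would give stronger inhibition than methyl.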